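Swapping the nitrophenyl for an ethylphenyl on the core

The source may report more compounds than this note shows. Statements on the series, on what has been measured and on what is new or still open speak of the compounds shown alone.

Compound 3 `C=CC(=O)Nc1cccc(NC(=O)CSc2nc(Nc3cccc([N+](=O)[O-])c3)c3ccccc3n2)c1` has the highest number of the three compounds measured in a functional assay on PC-3 cells (Homo sapiens) for inhibition, read by MTT assay, with a stated time of 72 h; a higher number here means a weaker inhibitor, a lower number a stronger inhibitor: compound 3 gives 46300 nM. Compound 1 `C=CC(=O)Nc1cccc(NC(=O)CSc2nc(Nc3ccccc3F)c3ccccc3n2)c1` gives 9340 nM, and compound 2 `C=CC(=O)Nc1cccc(NC(=O)CSc2nc(Nc3ccccc3C)c3ccccc3n2)c1` gives 23200 nM. The relevant steps are a 5.0-fold higher number from compound 1 to compound 3 (0.70 log units; beyond the scatter) and a 2.0-fold higher number from compound 2 to compound 3 (0.30 log units; within the scatter), both ending in a higher number. Compound 4 `C=CC(=O)Nc1cccc(NC(=O)CSc2nc(Nc3ccc(CC)cc3)c3ccccc3n2)c1` differs by 4-ethylphenyl in place of 3-nitrophenyl on a nitrogen on an aromatic ring. Among the measured compounds shown here, no measured step covers an ethyl group or this placement, so the guide is only that compound 2, which also carries an alkyl-substituted phenyl, gives 23200 nM. A modest drop in number is therefore expected. Compound 4 is estimated at 20000 nM, with a range from 7000 nM to 60000 nM. This corresponds to an expected step of a 2.3-fold lower number from compound 3 to compound 4 (0.36 log units; beyond the scatter).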

Compound 4, half-maximal inhibitory concentration: 24300 nM
Compound 4: the middle estimate sits 1.2-fold (0.08 log units) below what was measured; the measured number falls inside the stated range.
By their numbers in this assay, from the lowest: compound 1; then compounds 2, 4 and 3 (each within the scatter of the next).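

In this assay, 4-ethylphenyl on this nitrogen cannot be told apart from 3-nitrophenyl (a 1.9-fold lower number from compound 3 to compound 4 (0.28 log units; within the scatter)) or from 2-methylphenyl (a 1.0-fold higher number from compound 2 to compound 4 (0.02 log units; within the scatter)), even though the ethyl ring carries no nitrogen or oxygen. Among these four compounds, only 2-fluorophenyl stands apart (a 2.6-fold higher number from compound 1 to compound 4 (0.42 log units; beyond the scatter)), so compound 1 alone separates from the group. Nothing available explains that gap. From the compounds shown here alone, whether the fluoro group itself or its place on the ring sets compound 1 apart remains open. So does how an amine or a carboxylic acid on this ring would compare.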